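A few compounds are considered here, and "the series" means these few. Any claim that something is new, unique, unknown or untested is made for them only; others in the source may bear on it.

Measured in a functional assay on HeLa cells (Homo sapiens) for inhibition, read by MTT assay, with a stated time of 48 h; on this read-out higher numbers stand for weaker inhibition of growth and lower numbers for stronger inhibition of growth:
- Compound 1 `Cn1cc(C2CC(c3ccccc3)=NN2C(=O)c2cccnc2)c2cc(Br)ccc21`: 1730 nM
- Compound 2 `COc1ccc2c(c1)c(C1CC(c3ccccc3)=NN1C(=O)c1cccnc1)cn2C`: 3590 nM
- Compound 3 `COc1ccc2c(c1)c(C1CC(c3ccc(F)cc3)=NN1C(=O)c1ccc(OC)nc1)cn2C`: 410 nM

Compound 3 gives the lowest of these three numbers. Compound 4 `COc1cccc(C2=NN(C(=O)c3ccc(OC)nc3)C(c3cn(C)c4ccc(OC)cc34)C2)c1` differs from it as follows: 3-methoxyphenyl in place of 4-fluorophenyl on a carbon with a double bond to nitrogen. This places 3-methoxyphenyl in place of 4-fluorophenyl on a carbon with a double bond to nitrogen. Among the measured compounds shown here, no measured step touches that group. For the measured compounds named here, the only single change measured, methoxy in place of bromo on an aromatic carbon, is a 2.1-fold higher number from compound 1 to compound 2 (0.32 log units; beyond the scatter), a modest step beyond the scatter. It offers only a rough guide to size, so a modest loss in this assay is expected. The estimated change is a 1.7-fold higher number from compound 3 to compound 4 (0.23 log units; within the scatter). The value expected for compound 4 is 700 nM, with an estimated range from 250 nM to 2000 nM.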

Compound 4, concentration for 50% growth inhibition: 340 nM
Beside the measured number, compound 4's estimate is 2.1-fold (0.31 log units) above it; the range from low to high includes it.
By their numbers in this assay, from the lowest: compounds 4 and 3 (each within the scatter of the next); then compound 1; then compound 2.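

In this assay, among the compounds shown here, 3-methoxyphenyl in place of 4-fluorophenyl gives a 1.2-fold lower number from compound 3 to compound 4 (0.08 log units; within the scatter), the first measured change on this carbon with a double bond to nitrogen. The entering group carries a hydrogen-bond acceptor that 4-fluorophenyl lacks, yet the step stays within the scatter, so this exchange of aryl groups leaves the number essentially where it was. No measurement at hand bears on the reason for this result.

The compounds shown leave open how an amine or a carboxylic acid would fare at this position. They also leave open whether the same exchange would read alike on the bromo core of compound 1.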